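This account rests on a few compounds, and the source may have more. Where it says the series, first, only, none or still open, it means among the compounds named here.

Measured so far:
- compound 2, `Nc1nc(-c2ccc(OCc3cn(Cc4ccc(Br)cc4)nn3)cc2O)cc(-c2cccc3ccccc23)n1`: > 100000 nM
- compound 1, `C#CCOc1ccc(/C=C/C(=O)c2ccc(OCc3cn(Cc4ccccc4)nn3)cc2O)cc1`: "not determined" (no result reported)

Compound 1 carries no value in an ADME assay on cells (Macrophage) for cytotoxicity, read by resazurin assay, with a stated time of 48 h (a higher number here means that more compound is tolerated, a lower number that less compound is tolerated), and gives nothing to compare against. In this assay compound 2 gives > 100000 nM; this is a limit of the assay and not a number. Among the measured compounds shown here, compound 2 therefore stands at the limit of > 100000 nM in this assay, at which 1 of the 2 values shown sits, and the series as a whole holds no single measured number and no step between measured compounds.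

Compound 3, `Nc1nc(-c2ccccc2)cc(-c2ccc(OCc3cn(Cc4ccc(Br)cc4)nn3)cc2O)n1`, is yet to be measured. It differs from compound 2 by phenyl in place of naphthalen-1-yl on an aromatic carbon. For the measured compounds named here, with no measured step to lean on, the expectation is for no step beyond the scatter, most likely another limit. The expected step of a number no higher from compound 2 to compound 3 (the limit leaves the size open) is set at none. For compound 3 the estimate in this assay is 100000 nM, with a range from 30000 nM to 300000 nM, and a reported limit rather than a number is the likelier outcome.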

Compound 3, half-maximal cytotoxic concentration: > 100000 nM
Compound 3: no number, only a limit (the forecaster's own chance of this, stated with the estimate: 70%); the middle value lies on the limit itself.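

In this assay compound 3 gives > 100000 nM which is a limit of the assay and not a number, so no step can be read between compound 2 and compound 3. Still open, as far as these compounds go, is where the half-maximal cytotoxic concentration of either compound lies, and whether phenyl in place of naphthalen-1-yl shifts it at all.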